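Swapping the aryl group on the shared core: compound 2 to 3

The compounds below may be only part of what the source reports. "The series", "measured", "known", "first", "only" and "open" are said of these compounds alone.

Two compounds share the same core and were tested in a functional assay on HepG2 cells (Homo sapiens) for antiproliferative activity, read by CCK-8 assay, with a stated time of 72 h, tested at 2 uM; a lower number here means a weaker effect, a higher number a stronger effect of the compound at the concentration tested. Compound 1 `Nc1ccccc1NC(=O)c1ccc(COCNc2nc(Nc3ccccc3)c3ncn(C4CCCC4)c3n2)cc1` gives 37.5%. Compound 2 `Nc1ccccc1NC(=O)c1ccc(COCNc2nc(Nc3cccc(Cl)c3)c3ncn(C4CCCC4)c3n2)cc1` gives 32.6%. The only measured step, a number 4.9 percentage points lower from compound 1 to compound 2 (within the scatter), is within the scatter, so the two numbers cannot be told apart; compound 2 simply has the lower of the two numbers shown, with compound 1 the nearer and only other point.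

Compound 3 `Nc1ccccc1NC(=O)c1ccc(COCNc2nc(Nc3ccc(-c4ccccc4)cc3)c3ncn(C4CCCC4)c3n2)cc1` changes compound 2 as follows: 4-phenylphenyl in place of 3-chlorophenyl on a nitrogen on an aromatic ring. For the measured compounds named here, no measured step tests this kind of exchange; the single step from compound 1 to compound 2 concerns chloro in place of hydrogen, a different change, and it stayed within the scatter. With so little to go on, the expected step of a number 0.4 percentage points higher from compound 2 to compound 3 (within the scatter) is none beyond the scatter. Compound 3 is therefore estimated at 33%, with a range from 15% to 52%.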

Compound 3, a percentage reported as inhibition, at one concentration (the size of the read-out at that concentration, not a potency): 4.85%
For compound 3 the middle estimate is 28.2 percentage points above the measured one; the whole stated range lies above it.
By their numbers in this assay, from the lowest: compound 3; then compounds 2 and 1 (each within the scatter of the next).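

In this assay, the aryl group on this nitrogen is not free to change: a chloro on the ring left the number within the scatter, but a second benzene ring does not. Exchanging 3-chlorophenyl for 4-phenylphenyl gives a number 27.8 percentage points lower from compound 2 to compound 3 (beyond the scatter), and adding phenyl to the unsubstituted ring gives a number 32.7 percentage points lower from compound 1 to compound 3 (beyond the scatter), so compound 3 stands clearly apart from both earlier compounds. Nothing available explains this loss of effect at the tested concentration.

The compounds shown leave open whether the loss belongs to the second benzene ring itself or to where it sits on the first ring. They also leave open how a different group on that ring, such as an amine or a carboxylic acid, would read in this assay.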